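Macrocyclic aldehydes: cyclohexyl for isopropyl, cytotoxicity notes

A few compounds are considered here, and "the series" means these few. Any claim that something is new, unique, unknown or untested is made for them only; others in the source may bear on it.

The series comprises three measured macrocycles and one awaiting measurement. Compound 1 `CC(C)C[C@@H]1NC(=O)[C@@H](NC(=O)OCc2ccccc2)Cc2cn(nn2)CCNC(=O)CC[C@@H](C=O)NC1=O` was tested in an ADME assay on HG23 cells (Homo sapiens) for cytotoxicity, with a stated time of 72 h; on this read-out higher numbers stand for lower toxicity in this test and lower numbers for higher toxicity in this test. In this assay compound 1 reaches only a limit, > 100000 nM. Compound 2 `O=C[C@@H]1CCC(=O)NCCn2cc(nn2)C[C@H](NC(=O)OCc2ccccc2)C(=O)N[C@@H](CC2CCCCC2)C(=O)N1` likewise returns only a limit in this assay, > 100000 nM. Compound 3 `CC(C)C[C@@H]1NC(=O)[C@@H](NC(=O)OCc2ccccc2)Cc2cn(nn2)CCCCCNC(=O)CC[C@@H](C=O)NC1=O` also gives a limit in this assay, > 100000 nM. The step from compound 1 to compound 2 is a step that the two limits leave unreadable from compound 1 to compound 2; the structural change behind it is cyclohexyl in place of isopropyl on a saturated chain carbon bound to a saturated ring carbon. The cores of compound 1 and compound 3 differ, but that difference is not broken down here. Compound 4 `O=C[C@@H]1CCC(=O)NCCCCCn2cc(nn2)C[C@H](NC(=O)OCc2ccccc2)C(=O)N[C@@H](CC2CCCCC2)C(=O)N1` differs from compound 3 by cyclohexyl in place of isopropyl on a saturated chain carbon bound to a saturated ring carbon, the same change as from compound 1 to compound 2, at the same place. The step expected from compound 3 to compound 4 in this assay is a step that the limit leaves unreadable from compound 3 to compound 4, resting on the limit of > 100000 nM in this assay, at which 3 of the 3 values shown sit, and on a step that the two limits leave unreadable from compound 1 to compound 2. Compound 4 is therefore expected to show 150000 nM, with a range from 60000 nM to 400000 nM. Whether this assay again reports only a limit for compound 4 remains to be seen.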

Compound 4, half-maximal cytotoxic concentration: > 100000 nM
Compound 4 gave a limit, no number; the forecaster's own chance of this, stated with the estimate: 85%; the middle value lies beyond the limit too.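

The step from compound 3 to compound 4 cannot be read, and the same holds for the step from compound 1 to compound 2, as each pair gives only limits in this assay: the limit of > 100000 nM in this assay, at which 4 of the 4 values shown sit.

The compounds shown leave open whether cyclohexyl in place of isopropyl changes the half-maximal cytotoxic concentration at all, and at what concentration any of the four compounds would give a number in this assay.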